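This account rests on a few compounds, and the source may have more. Where it says the series, first, only, none or still open, it means among the compounds named here.

Measured in a functional assay on OVCAR-4 cells (Homo sapiens) for antiproliferative activity, read by WST assay, with a stated time of 3 days; a higher number here means a weaker inhibitor, a lower number a stronger inhibitor:
- compound 1 `O=c1cc(I)n([C@@H]2O[C@H](CO)[C@@H](O)[C@H]2O)c(=O)[nH]1`: > 50000 nM (a limit)
- compound 2 `O=c1[nH]c(=O)n([C@@H]2O[C@H](CO)[C@@H](O)[C@H]2O)c(I)c1F`: > 50000 nM (a limit)
- compound 3 `O=Cc1c(F)c(=O)[nH]c(=O)n1[C@@H]1O[C@H](CO)[C@@H](O)[C@H]1O`: "not determined" (no result reported)

Compound 2 gives > 50000 nM, which is a limit and not a number. It therefore stands with compound 1 at the limit of > 50000 nM in this assay, at which 2 of the 3 values shown sit.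

Compound 4 `O=c1[nH]c(=O)n([C@@H]2O[C@H](CO)[C@@H](O)[C@H]2O)c(I)c1Br` differs from compound 2 by one change, bromo in place of fluoro on an aromatic carbon.

Among the measured compounds shown here, the only measured step that bears on this change is a step that the two limits leave unreadable from compound 1 to compound 2, at the same carbon, and it gives no size to carry over. No clear direction can therefore be expected in this assay.

The expected step is a number no higher from compound 2 to compound 4 (the limit leaves the size open), which is only a rough estimate.

For compound 4 the estimated value is 50000 nM, with an expected range from 20000 nM to 100000 nM.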

Compound 4, half-maximal inhibitory concentration: > 50000 nM
Compound 4: only a limit was reported; the forecaster's own chance of this, stated with the estimate: 85%; the middle value sits exactly at the limit.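

In this assay, among the compounds shown here, compound 1, compound 2 and compound 4 all give only a limit, not a number, so no step among them can be read. As far as these compounds go, whether hydrogen, fluoro or bromo on this aromatic carbon makes any difference to antiproliferative activity stays open.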